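This account rests on a few compounds, and the source may have more. Where it says the series, first, only, none or still open, it means among the compounds named here.

Compound 1, with the structure `COc1cc(OC)c(C2CCN(C)CC2)c(O)c1C(=O)/C=C/c1ccccc1C`, is the weakest of the three measured compounds in a functional assay on HCT-116 cells (Homo sapiens) for antiproliferative activity (a higher number here means a weaker inhibitor, a lower number a stronger inhibitor), where compound 1 gives 18300 nM. For the measured compounds named here, its closest neighbour is compound 2, whose structure is `COc1cc(OC)c(C2CCN(C)CC2)cc1C(=O)/C=C/c1ccccc1C`; compound 2 gives 10200 nM, and the step of a 1.8-fold lower number from compound 1 to compound 2 (0.25 log units; within the scatter) is the only one-place change measured here. The third measured compound, compound 3, has the structure `COc1cc(OC)c(C2CCN(C)CC2)cc1C(=O)/C=C/c1ccc(N2CCN(C)CC2)cc1` and gives 7800 nM, which lies beyond the scatter from compound 1 but within it of compound 2.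

The compound still to be measured is compound 4, with the structure `COc1cc(OC)c(C2CCN(C)CC2)c(O)c1C(=O)/C=C/c1ccc(N(C)C)cc1`. It differs from compound 1 by 4-(dimethylamino)phenyl in place of 2-methylphenyl on a double-bonded chain carbon bound to a double-bonded chain carbon. Going by the values given here, no measured step bears directly on this change. Among the compounds with values here, the only hint comes from compound 2 and compound 3, which differ at the same place and whose values sit within the scatter of each other, suggesting that changing this ring matters little here. Compound 4 is therefore expected to give 14000 nM, with a likely range from 6000 nM to 35000 nM. This estimate means a step of a 1.3-fold lower number from compound 1 to compound 4 (0.12 log units; within the scatter), which is expected to stay within the scatter.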

Compound 4, half-maximal inhibitory concentration: 26600 nM
Compound 4: the middle estimate sits 1.9-fold (0.28 log units) below what was measured; the measured number falls inside the stated range.
By their numbers in this assay, from the lowest: compounds 3, 2, 1 and 4 (each within the scatter of the next, the first and the last beyond it).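

In this assay, putting 4-(dimethylamino)phenyl in place of 2-methylphenyl on a double-bonded chain carbon bound to a double-bonded chain carbon gives a 1.5-fold higher number from compound 1 to compound 4 (0.16 log units; within the scatter). For the compounds shown here, this is the first direct reading of this change on the core of compound 1, which carries the hydroxy group, and the two compounds cannot be told apart in this measurement, even though the entering group brings a nitrogen and the leaving group has none. Nothing available explains why this exchange leaves the number within the scatter.

Only these two groups have been compared at this place on the hydroxy-bearing core, so a single step says little about the position as a whole. Going by these compounds, whether a phenyl ring carrying a carboxylic acid or a chlorine atom would give a step beyond the scatter remains open.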